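The source may report more compounds than this note shows. Statements on the series, on what has been measured and on what is new or still open speak of the compounds shown alone.

Compound 2 `O=C(/C=C\Nc1ccc(Cl)cc1)c1nc(-c2ccc(F)cc2)n2ccccc12` gives, in a functional assay on A549 cells (Homo sapiens) for cytotoxicity, read by MTT assay, with a stated time of 48 h (a higher number here means a weaker inhibitor, a lower number a stronger inhibitor), a value of 5090 nM, which is the lowest of the two numbers recorded so far. Within the data shown here, its only neighbour is compound 1 `O=C(/C=C\Nc1ccc(F)cc1)c1nc(-c2ccc(F)cc2)n2ccccc12`, which in this assay gives 13200 nM; the step of a 2.6-fold lower number from compound 1 to compound 2 (0.41 log units; beyond the scatter) comes from chloro in place of fluoro on an aromatic carbon and lies beyond the scatter, though it is a modest one. Compound 3 `Cc1cc2cc(N/C=C\C(=O)c3nc(-c4ccc(F)cc4)n4ccccc34)ccc2[nH]1` has not yet been measured in this assay. It differs from compound 2 in one place: 2-methyl-1H-indol-5-yl in place of 4-chlorophenyl on an amine nitrogen. Among the measured compounds shown here, the only measured step, the one from compound 1 to compound 2, concerns a halogen swap at this same aryl group and does not speak directly to replacing the whole ring by a bicyclic one carrying a hydrogen-bond donor. The expectation for compound 3 therefore rests on a single modest step and is wide: the estimated change a 1.3-fold lower number from compound 2 to compound 3 (0.10 log units; within the scatter) is taken as small, with a value expected near 4000 nM, plausibly between 1000 nM and 16000 nM.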

Compound 3, half-maximal inhibitory concentration: > 30000 nM
Compound 3: only a limit was reported; the forecaster's own chance of this, stated with the estimate: 5%; middle value at least 7.5-fold (0.87 log units) from the limit.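

In this assay, the value of compound 3 is a limit of the assay and not a number: the limit of > 30000 nM in this assay, at which 1 of the 3 values shown sits. Even so, both steps to it can be read: 2-methyl-1H-indol-5-yl in place of 4-chlorophenyl on the amine nitrogen gives an at least 5.8-fold higher number from compound 2 to compound 3 (0.77 log units; beyond the scatter), and the same group in place of 4-fluorophenyl gives an at least 2.2-fold higher number from compound 1 to compound 3 (0.35 log units; beyond the scatter). The earlier compounds shown here showed only a halogen exchange on the phenyl ring at this position, whereas these steps show that exchanging the whole aryl group for this bicyclic one moves the number upward, past both halogen compounds and beyond the scatter.

The compounds shown do not separate the contributions of the added five-membered ring, its ring nitrogen with the hydrogen it carries, and the methyl group, and they do not show how far the value of compound 3 lies past the limit. Going by these compounds, it also remains open whether an unsubstituted 1H-indol-5-yl, a naphthyl group with carbon rings only, or a 4-methoxyphenyl group on the same amine nitrogen would stay close to the two halogen compounds.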